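Hydrogen in place of methyl: compound 1 to compound 3

The compounds below may be only part of what the source reports. "The series", "measured", "known", "first", "only" and "open" are said of these compounds alone.

Among the measured compounds shown here, in a toxicity assay on L6 cells (Rattus norvegicus) for cytotoxicity, read by resazurin assay, with a stated time of 70 h (on this read-out lower numbers stand for stronger inhibition and higher numbers for weaker inhibition), compound 1 (`CCC(C)NC(=O)c1nc(-c2cccc(C)c2)cnc1N`) gives 43000 nM and holds the higher of the two numbers so far. Compound 2 (`CCC(CC)NC(=O)c1nc(-c2ccccc2C#N)cnc1N`) gives 10000 nM on the same read-out, a lower number by more than the usual scatter. For the measured compounds named here, these two compounds differ in more than one place, so they offer no step for the change at hand.

Compound 3 (`CCC(C)NC(=O)c1nc(-c2ccccc2)cnc1N`) is still unmeasured. It differs from compound 1 as follows: hydrogen in place of methyl on an aromatic carbon (hydrogen in place of methyl on an aromatic carbon, or 3-methylphenyl to phenyl). Going by the values given here, the series holds no measured example of this change, so the expectation starts from compound 1 at 43000 nM and assumes no shift. The expected step is a 1.0-fold higher number from compound 1 to compound 3 (0.02 log units; within the scatter) and it is estimated to stay within the scatter. Compound 3 is estimated at 45000 nM with a range from 18000 nM to 100000 nM in this assay before measurement.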

Compound 3, half-maximal inhibitory concentration: 18000 nM
Compound 3: the middle estimate sits 2.5-fold (0.40 log units) above what was measured; the measured number falls inside the stated range.
By their numbers in this assay, from the lowest: compounds 2 and 3 (each within the scatter of the next); then compound 1.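

In this assay, among the compounds shown here, the change from 3-methylphenyl to phenyl gives the series its only step between compounds that differ in one place: a 2.4-fold lower number from compound 1 to compound 3 (0.38 log units; beyond the scatter). It shows that the methyl on this aromatic carbon, meta to a large group, is not neutral on this read-out, and that its loss goes with a modest move to a lower number with the rest of compound 1 unchanged. Nothing available on the compounds accounts for the direction or size of this step.

This single pair leaves open whether the number at this place follows the size of the group or its kind, which a longer chain, a methoxy group, a chlorine atom or an amine there could begin to separate. It also leaves open whether the same change gives a similar step with a different group on the amide.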